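The source may report more compounds than this note shows. Statements on the series, on what has been measured and on what is new or still open speak of the compounds shown alone.

Working notes on the series. Compound 1 `Cc1cccc(Cn2c(CN3CCN(C(=O)C4CCCC4)CC3)nc3ccccc32)c1` has the cyclopentylcarbonyl on the ring nitrogen and has the higher number of the two compounds measured in an assay on isolated protein for inhibition of aldehyde dehydrogenase 1A1 (Homo sapiens), read by spectrophotometry, tested at 10 uM; a lower number here means less inhibition, a higher number more inhibition at the concentration tested (going by the name of the read-out): compound 1 gives 67.5%. Compound 2 `O=C(C1CC1)N1CCN(Cc2nc3ccccc3n2Cc2ccccc2)CC1` carries a cyclopropylcarbonyl in the same position and lacks the methyl on the benzyl group; in this assay compound 2 gives 23.9%, a number well below that of compound 1 and beyond the usual scatter. For the measured compounds named here, compound 2 differs from compound 1 in two places at once, so no single step between measured compounds is available to read from.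

Compound 3 `Cc1cccc(Cn2c(CN3CCN(C(=O)C(C)C)CC3)nc3ccccc32)c1` is the next compound to be measured. It differs from compound 1 in one place only: isopropyl in place of cyclopentyl on a carbonyl carbon. The change keeps the amide and the rest of the shared core of compound 1 and removes the ring of the acyl group, leaving a shorter branched chain on the carbonyl carbon.

Going by the values given here, with no measured single step to rest on, a moderate loss is expected in this assay, so that the step of a number 17.5 percentage points lower from compound 1 to compound 3 (beyond the scatter) is estimated to fall somewhat beyond the scatter. Compound 3 is therefore expected to give about 50%, with a likely range from 30% to 70%.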

Compound 3, a percentage reported as inhibition, at one concentration (the size of the read-out at that concentration, not a potency): 87.2%
The estimate for compound 3 lay 37.2 percentage points below the measured number; the whole stated range lies below it.
By their numbers in this assay, from the lowest: compound 2; then compound 1; then compound 3.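

In this assay, for the compounds shown here, isopropyl in place of cyclopentyl on a carbonyl carbon gives a number 19.7 percentage points higher from compound 1 to compound 3 (beyond the scatter) and provides the first single-place reading. At this position, the five-membered non-aromatic ring of carbon only is therefore not required for inhibition at the concentration tested, and compound 3, with an open branched group of 3 heavy atoms in place of 5, gives 87.2% with the amide and the shared core of compound 1 unchanged. Nothing available for this pair bears on why the number rises.

The compounds shown leave open whether the number would hold or change with a methyl, an ethyl, a tert-butyl or a longer chain on the carbonyl carbon, and whether an amine or a carboxylic acid would be accepted on the acyl group. The methyl on the benzyl group also remains without a single-place step of its own, so its contribution in this series cannot yet be read.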